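A few compounds are considered here, and "the series" means these few. Any claim that something is new, unique, unknown or untested is made for them only; others in the source may bear on it.

Measured compounds:

compound 1, `CNC(=O)C[C@@H]1C[C@@H](c2ccc(Cl)c(Cl)c2)[C@H](NC(=O)c2cc(-c3c(Cl)cnn3C)c(Cl)o2)CN1`, in a functional assay on OVCAR-8 cells (Homo sapiens) for antiproliferative activity (a higher number here means a weaker inhibitor, a lower number a stronger inhibitor), compound 1 gives 1130 nM
compound 2, `Cn1ncc(Cl)c1-c1cc(C(=O)N[C@@H]2CNCC[C@H]2c2ccc(C(F)(F)F)cc2)oc1Cl`, in this assay compound 2 gives 120 nM
compound 3, `Cn1ncc(Cl)c1-c1cc(C(=O)N[C@@H]2CN[C@H](CCO)C[C@H]2c2ccc(F)c(F)c2)oc1Cl`, in this assay compound 3 gives 460 nM

Among these three, compound 1 stands at the highest number in this assay. Its nearest neighbour is compound 3, whose value is lower by a margin that goes beyond the usual scatter, and compound 2 sits furthest away, at a considerably lower number again. No two of these compounds differ in only one place, so the numbers alone are all that can be said of them side by side.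

The unmeasured compound 4, `CN(C)CC[C@@H]1C[C@@H](c2ccc(Cl)c(Cl)c2)[C@H](NC(=O)c2cc(-c3c(Cl)cnn3C)c(Cl)o2)CN1`, is built from compound 1 by one change: (dimethylamino)methyl in place of methylcarbamoyl on a saturated chain carbon bound to a saturated ring carbon. The group that leaves and the group that enters are of the same size, and the shared core is untouched. Going by the values given here, none of the measured pairs offers a step of this kind, so there is no comparable precedent to lean on. He expects the step of a 1.6-fold lower number from compound 1 to compound 4 (0.21 log units; within the scatter) in this assay to be small and directed toward a lower number, but not clearly beyond the scatter. For compound 4 he estimates 700 nM, within a range from 250 nM to 2000 nM.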

Compound 4, half-maximal inhibitory concentration: 1510 nM
Compound 4: middle estimate off by 2.2-fold (0.33 log units), on the low side; measured number inside the range.
By their numbers in this assay, from the lowest: compound 2; then compound 3; then compounds 1 and 4 (each within the scatter of the next).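

In this assay, the first step read at this position, methylcarbamoyl to (dimethylamino)methyl on a saturated chain carbon bound to a saturated ring carbon, gives a 1.3-fold higher number from compound 1 to compound 4 (0.13 log units; within the scatter), which leaves the two compounds indistinguishable. The exchange keeps the count of 4 heavy atoms but takes away the one hydrogen-bond donor and the double bond outside aromatic rings, and on this core the number does not move beyond the scatter. No measurement shown here speaks to why this is so.

As far as these compounds go, it remains open whether a carboxylic acid, a morpholine or a longer chain at this position would shift the number beyond the scatter. From the compounds shown here alone, it is also open whether the same exchange would give a comparable step on a core that carries a group other than the dichlorophenyl.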